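From chloro to bromo on the aryl ring

The compounds below may be only part of what the source reports. "The series", "measured", "known", "first", "only" and "open" are said of these compounds alone.

Compound 1 `CN1CCN(c2ccc(-c3cc(-c4ccc(C5NC(=O)c6ccccc6N5)cc4)nc(N)n3)cc2)CC1`: 8320 nM
Compound 2 `Nc1nc(-c2ccc(Cl)cc2)cc(-c2ccc(C3NC(=O)c4ccccc4N3)cc2)n1`: 323000 nM

In an ADME assay on Vero cells (Chlorocebus sabaeus) for cytotoxicity, read by MTT assay, with a stated time of 72 h (on this read-out lower numbers stand for higher toxicity in this test and higher numbers for lower toxicity in this test), compound 2 holds the higher of the two numbers, at 323000 nM. Compound 3 `Nc1nc(-c2ccc(Br)cc2)cc(-c2ccc(C3NC(=O)c4ccccc4N3)cc2)n1` differs from it by one change: bromo in place of chloro on an aromatic carbon. Among the compounds with values here, the only measured step nearby is a 39-fold higher number from compound 1 to compound 2 (1.59 log units; beyond the scatter), which is large and beyond the scatter. That step brought in chloro in place of 4-methylpiperazin-1-yl, so it offers no direct measure of the bromo exchange. No size of change beyond the scatter is therefore expected, and the estimate is a 1.2-fold lower number from compound 2 to compound 3 (0.06 log units; within the scatter). Compound 3 is expected at 280000 nM, with an estimated range of 120000 nM to 600000 nM.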

Compound 3, half-maximal cytotoxic concentration: > 400000 nM
Compound 3 gave a limit, no number; the forecaster's own chance of this, stated with the estimate: 15%; at least 1.4-fold (0.15 log units) between middle value and limit.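

In this assay compound 3 gives > 400000 nM, which is a limit of the assay and not a number. Bromo in place of chloro on this aromatic carbon gives an at least 1.2-fold higher number from compound 2 to compound 3 (0.09 log units; that floor lies within the scatter), so the floor of the step lies within the scatter and its full size stays unread. Measured against 4-methylpiperazin-1-yl, bromo gives an at least 48-fold higher number from compound 1 to compound 3 (1.68 log units; beyond the scatter), so chloro and bromo alike stand beyond the scatter from that group.

Still open, as far as these compounds go, is whether a smaller amine such as dimethylamino, or a carboxylic acid, at this position would read like the two halogens or like the 4-methylpiperazin-1-yl group.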